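Bromo to methoxy on the aryl ring of a pyrazoline series

This account rests on a few compounds, and the source may have more. Where it says the series, first, only, none or still open, it means among the compounds named here.

Two compounds of this series have numbers in a functional assay on BGC-823 cells (Homo sapiens) for inhibition, read by CCK-8 assay, with a stated time of 48 h; on this read-out higher numbers stand for weaker inhibition and lower numbers for stronger inhibition. Compound 1 `Brc1ccc(C2=NN(C3=NC(c4ccccc4)CS3)C(c3ccc4ccccc4c3)C2)cc1` gives 13000 nM. Compound 2 `O=C1CSC(N2N=C(c3ccc(Br)cc3)CC2c2cccc3ccccc23)=N1` gives 14600 nM, the highest of the two numbers; its nearest neighbour is compound 1, and the gap between them lies within the scatter, so the two cannot be told apart. Compound 3 `COc1ccc(C2=NN(C3=NC(=O)CS3)C(c3cccc4ccccc34)C2)cc1` has not been measured. It differs from compound 2 in one place: methoxy in place of bromo on an aromatic carbon. Going by the values given here, no measured pair shows this exchange, so nothing tells how methoxy in place of bromo at this position moves the read-out. Among the compounds with values here, with only two compounds, both weak and indistinguishable, the step of a 1.0-fold higher number from compound 2 to compound 3 (0.01 log units; within the scatter) is expected to stay within the scatter, in no fixed direction. Compound 3 is therefore expected to give about 15000 nM in this assay, with a range from 6000 nM to 40000 nM.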

Compound 3, half-maximal inhibitory concentration: 8210 nM
For compound 3 the middle estimate is 1.8-fold (0.26 log units) above the measured one; the measured number falls inside the stated range.
By their numbers in this assay, from the lowest: compounds 3, 1 and 2 (each within the scatter of the next).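

Going by these compounds alone, the exchange of 4-bromophenyl for 4-methoxyphenyl gives the first reading at this position: in this assay it is a 1.8-fold lower number from compound 2 to compound 3 (0.25 log units; within the scatter) and so does not separate the two compounds. Bromo can thus give way to methoxy, with one more heavy atom and one hydrogen-bond acceptor, without a change in the read-out that exceeds the scatter, and this holds for this single pair on the core of compound 2 only. No measurement on hand bears on what lies behind this result.

Still open, as far as these compounds go, is whether an amine, a carboxylic acid or a longer chain such as ethoxy at this position would move the read-out beyond the scatter. Also open, from the compounds shown here alone, is whether methoxy in place of bromo reads the same on the core of compound 1.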